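Removing the Benzyl Group: From Compound 3 to Compound 4

The source may hold more compounds than are shown below. What is called first, only, known or untested is meant among the compounds shown, and "the series" means these compounds.

Compound 1, `O=C(CCCc1cn(C(=O)c2ccc(Cl)cc2)c2ccccc12)N1CCOCC1`: 32.4%
Compound 2, `O=C(CCc1cn(C(=O)c2ccccc2)c2ccccc12)N1CCOCC1`: 23.4%
Compound 3, `COc1ccc2c(c1)c(CCCC(=O)N1CCOCC1)c(C)n2Cc1ccccc1`: 54.2%

Of the compounds shown here, three have been measured in an assay on cells for inhibition of Polyunsaturated fatty acid 5-lipoxygenase (Rattus norvegicus), tested at 5 uM; on this read-out higher numbers stand for more inhibition at the one concentration tested (going by the name of the read-out) and lower numbers for less inhibition. In that assay compound 1 gives 32.4%, compound 2 gives 23.4%, and compound 3 gives 54.2%. Compound 3 stands highest of the three numbers; its nearest neighbour is compound 1, lower by a margin beyond the scatter, and the furthest is compound 2, lower by a margin that also lies beyond the scatter. Among the compounds with values here, no two of these three compounds differ in only one place, so no single step between measured compounds can be read from them.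

Compound 4, `COc1ccc2[nH]c(C)c(CCCC(=O)N3CCOCC3)c2c1`, has not yet been measured. Compared with compound 3 the change is this: hydrogen in place of benzyl on an aromatic nitrogen. Within the data shown here, every measured compound carries a larger group on that aromatic nitrogen, and none carries hydrogen there, so the series holds no direct precedent for this step.

The step is expected to be a decrease beyond the scatter, namely a number 24.2 percentage points lower from compound 3 to compound 4 (beyond the scatter). Compound 4 is therefore estimated to give 30%, with a likely range from 10% to 52%.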

Compound 4, a percentage reported as inhibition, at one concentration (the size of the read-out at that concentration, not a potency): 72.9%
The estimate for compound 4 lay 42.9 percentage points below the measured number; measured number above the stated range.
By their numbers in this assay, from the lowest: compounds 2 and 1 (each within the scatter of the next); then compound 3; then compound 4.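

In this assay the change gives a number 18.7 percentage points higher from compound 3 to compound 4 (beyond the scatter), so on this pair the aromatic nitrogen does not need the benzyl group for inhibition at the one concentration tested: with only hydrogen there, the number rises. The earlier compounds shown here could not show this, as all of them carry a larger group on that nitrogen and no two of them differ in only one place. The data shown offer no explanation for the rise.

On these data alone, what remains open is whether hydrogen itself is best on this nitrogen, or whether a small group such as ethyl or acetyl would give a similar number, and whether the same step would hold with the other parts of compound 4 changed, for example with a carboxylic acid in place of the morpholine amide. Within the data shown here, a single pair also cannot say whether the step from benzyl to hydrogen would carry over to other members, and a reading at one concentration gives no potency for either compound.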